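This account rests on a few compounds, and the source may have more. Where it says the series, first, only, none or still open, it means among the compounds named here.

Compound 1, `C=C1C(=O)OC[C@H]1CCOC(=O)Nc1ccc(C(C)C)cc1`, gives 12400 nM in an ADME assay on RAW264.7 cells (Mus musculus) for cytotoxicity, read by MTT assay, with a stated time of 18 h; on this read-out lower numbers stand for higher toxicity in this test and higher numbers for lower toxicity in this test.
Compound 2, `C=C1C(=O)OC[C@@H]1CCOC(=O)Nc1ccc(I)cc1`, gives 12500 nM in this assay.

Within the data shown here, only two compounds have been measured, and their numbers sit essentially on top of each other: compound 1 has the lower of the two, but the gap to compound 2 is well within the scatter, so no order can be read between them. Compound 3, `C=C1C(=O)OC[C@H]1CCOC(=O)Nc1ccc(OC)cc1`, has not yet been measured. It differs from compound 1 in one place: methoxy in place of isopropyl on an aromatic carbon. Among the measured compounds shown here, no step between measured compounds that resembles this swap is available, so the expectation rests on how little the two measured values differ from each other. Accordingly, the step of a 1.0-fold lower number from compound 1 to compound 3 (0.01 log units; within the scatter) is expected to be small, with no direction beyond the scatter. Compound 3 is thus estimated to give 12000 nM, in a range from 5000 nM to 30000 nM.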

Compound 3, half-maximal cytotoxic concentration: 12400 nM
Beside the measured number, compound 3's estimate is 1.0-fold (0.01 log units) below it, within the range that was stated.
By their numbers in this assay, from the lowest: compounds 1, 3 and 2 (each within the scatter of the next).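

Among these compounds, this is the first step between measured compounds that differ in one place: in this assay, methoxy in place of isopropyl, on an aromatic carbon para to a large group, gives no change at the digits printed from compound 1 to compound 3 (within the scatter) on the half-maximal cytotoxic concentration. For this pair, then, replacing an all-carbon group with one that carries an oxygen and a hydrogen-bond acceptor does not shift the read-out beyond the scatter. Nothing available explains why the two groups read alike.

As far as these compounds go, whether an amine, a carboxylic acid or a longer chain at this position would also leave the number where it stands remains open. A single pair also cannot show whether the same swap would read alike on a different core.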